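Amino for chloro on the fused core of compound 3

The source may report more compounds than this note shows. Statements on the series, on what has been measured and on what is new or still open speak of the compounds shown alone.

Compound 1 `ClCc1cccc(Cn2cnc3ncnc(Cl)c32)c1`: 5370 nM
Compound 2 `ClCc1cccc(Cn2cnc3c(Cl)ncnc32)c1`: 18200 nM
Compound 3 `ClCc1cccc(Cn2cnc3c(Cl)nc(Cl)nc32)c1`: 5010 nM

In a functional assay on PC-3 cells (Homo sapiens) for cytotoxicity, read by sulforhodamine B assay, with a stated time of 48 h (on this read-out lower numbers stand for stronger inhibition of growth and higher numbers for weaker inhibition of growth), compound 3 gives the lowest number of the three, though compound 1 sits within the scatter of it; only compound 2 stands clearly apart. Compound 4 `Nc1nc(Cl)c2ncn(Cc3cccc(CCl)c3)c2n1` differs from compound 3 by amino in place of chloro on an aromatic carbon. Among the compounds with values here, the one measured step that touches this place is a 3.6-fold lower number from compound 2 to compound 3 (0.56 log units; beyond the scatter), which shows that a chloro group there, in place of hydrogen, lowered the number. Nothing shows what an amino group there does, so an expectation rests on that single step only. A step of a 1.4-fold higher number from compound 3 to compound 4 (0.15 log units; within the scatter) is expected, meaning no change beyond the scatter or a small loss. Compound 4 is estimated at 7000 nM, in a range from 2500 nM to 20000 nM.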

Compound 4, concentration for total growth inhibition: 25100 nM
Beside the measured number, compound 4's estimate is 3.6-fold (0.55 log units) below it, and the stated range ends below it.
By their numbers in this assay, from the lowest: compounds 3 and 1 (each within the scatter of the next); then compounds 2 and 4 (each within the scatter of the next).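

In this assay, the position between two ring nitrogen atoms distinguishes chloro from amino: the change gives a 5.0-fold higher number from compound 3 to compound 4 (0.70 log units; beyond the scatter) and so does not keep the lower number seen with chloro. Amino in place of hydrogen gives a 1.4-fold higher number from compound 2 to compound 4 (0.14 log units; within the scatter) and so brings no change beyond the scatter, leaving chloro as the only group shown here that lowers the number. Nothing available explains this difference.

From the compounds shown here alone, it remains open whether bromo or methoxy at this position would track chloro or amino. A methylamino group would test whether the loss extends beyond amino itself.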